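The compounds below may be only part of what the source reports. "The series", "measured", "known", "first", "only" and "open" are said of these compounds alone.

Compound 2 `CCc1ccccc1OC1CCN(c2ccc(-n3ccnc3)nn2)CC1` stands lowest among the three compounds measured in an assay on microsomes from liver for inhibition of acyl-CoA desaturase 1 (Rattus norvegicus) (on this read-out lower numbers stand for stronger inhibition and higher numbers for weaker inhibition), where compound 2 gives 4 nM. Compound 1 `CC(C)c1nnc(-c2ccc(N3CCC(Oc4ccccc4C(F)(F)F)CC3)nn2)s1` gives 8.8 nM and compound 3 `CC(C)(C)c1nnc(-c2ccc(N3CCC(Oc4ccccc4C(F)(F)F)CC3)nn2)o1` gives 980 nM. Going by the values given here, the only measured step, a 110-fold higher number from compound 1 to compound 3 (2.05 log units; beyond the scatter), changes a group on an aromatic carbon and says nothing about the part of the molecule altered here. Compound 4 `c1cn(-c2ccc(N3CCC(Oc4ccc5c(c4)CCC5)CC3)nn2)cn1` differs from compound 2 by 2,3-dihydro-1H-inden-5-yl in place of 2-ethylphenyl on an oxygen on a saturated carbon. Among the compounds with values here, no measured step touches this position, so only a small shift, if any beyond the scatter, is expected in this assay. A slight weakening is the estimated direction, amounting to a 2.0-fold higher number from compound 2 to compound 4 (0.30 log units; within the scatter). Compound 4 is therefore expected to give 8 nM in this assay, within a range from 2 nM to 40 nM.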

Compound 4, half-maximal inhibitory concentration: 62 nM
For compound 4 the middle estimate is 7.8-fold (0.89 log units) below the measured one, and the stated range ends below it.
By their numbers in this assay, from the lowest: compound 2; then compound 1; then compound 4; then compound 3.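

In this assay, going by these compounds alone, the group on this oxygen proves to matter: 2,3-dihydro-1H-inden-5-yl in place of 2-ethylphenyl gives a 16-fold higher number from compound 2 to compound 4 (1.19 log units; beyond the scatter) and thus a large weakening that the earlier compounds could not reveal. The entering group adds a five-membered non-aromatic ring, while neither group has hydrogen-bond donors or acceptors. Nothing available explains why this change has so large an effect.

Going by these compounds, whether the shift comes from losing the ethyl group or from adding the ring remains open. It is also unknown whether a plain phenyl or a 2-methoxyphenyl on this oxygen would give a number closer to that of compound 2 or compound 4.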